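A few compounds are considered here, and "the series" means these few. Any claim that something is new, unique, unknown or untested is made for them only; others in the source may bear on it.

Measured in a functional assay on MCF7 cells (Homo sapiens) for antiproliferative activity (a lower number here means a stronger inhibitor, a higher number a weaker inhibitor), so far:
- compound 1 `COc1ccc(C(=O)Nc2cc3ccc(OC4CCN(C)CC4)c(C)c3oc2=O)cc1CC=C(C)C` gives 1580 nM 
- compound 2 `Cc1c(OC2CCN(C)CC2)ccc2cc(NC(=O)c3ccc(O)cc3)c(=O)oc12` gives 1430 nM 

Compound 1 stands level with compound 2, as the two numbers lie within the scatter of each other. Compound 3 `CC(C)=CCc1cc(C(=O)Nc2cc3ccc(OC4CCN(C)CC4)c(C)c3oc2=O)ccc1OCCCN(C)C` keeps the core of compound 1 but carries 3-(dimethylamino)propoxy in place of methoxy (2-(dimethylamino)ethyl in place of hydrogen on a saturated chain carbon bound to an oxygen on an aromatic ring), which amounts to 2-(dimethylamino)ethyl in place of hydrogen on a saturated chain carbon bound to an oxygen on an aromatic ring. For the measured compounds named here, no measured pair shows what this change does in this assay, so only a small step toward a lower number is expected. The estimate means a 1.9-fold lower number from compound 1 to compound 3 (0.27 log units; within the scatter) as the expected step. For compound 3 the estimated value is 850 nM, with an expected range of 300 nM to 2400 nM here.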

Compound 3, half-maximal inhibitory concentration: 460 nM
Estimate against measurement, compound 3: 1.8-fold (0.27 log units) above; the range from low to high includes it.
By their numbers in this assay, from the lowest: compound 3; then compounds 2 and 1 (each within the scatter of the next).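

In this assay, methoxy gives way to 3-(dimethylamino)propoxy on the shared core, with a 3.4-fold lower number from compound 1 to compound 3 (0.54 log units; beyond the scatter) as the result. This shows that the number responds to a change at this place on the ring, a saturated chain carbon bound to an oxygen on an aromatic ring, which the earlier comparison of two level compounds could not reveal. No measurement here accounts for the step. The compounds shown leave open whether 2-(dimethylamino)ethoxy, a shorter chain, would give a similar step. They also leave open whether a carboxylic acid at the chain end would do so in place of the dimethylamino group.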